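The source may hold more compounds than are shown below. What is called first, only, known or untested is meant among the compounds shown, and "the series" means these compounds.

Measured so far:
- compound 1 `O=C1O[C@@H](CN2CCC(O)CC2)CN1c1ccc(-n2cc(-c3ccccn3)cn2)c(F)c1`: in an ADME assay on HEK293-A cells (Homo sapiens) for cytotoxicity, read by MTT assay, with a stated time of 48 h (on this read-out higher numbers stand for weaker inhibition and lower numbers for stronger inhibition), compound 1 gives > 400 ug/mL
- compound 2 `O=C1CNC(=O)N1C[C@H]1CN(c2ccc(-n3cc(-c4ccccn4)cn3)c(F)c2)C(=O)O1`: compound 2 gives > 400 ug/mL
- compound 3 `O=C(NC[C@H]1CN(c2ccc(-n3cc(-c4ccccn4)cn3)c(F)c2)C(=O)O1)C(F)F`: compound 3 gives 167 ug/mL

Compound 1 stands at a limit of this assay rather than at a number, so its cytotoxicity is only bounded, not placed. Compound 2 sits at the same limit; (the limit of > 400 ug/mL in this assay, at which 2 of the 3 values shown sit), so the move from compound 1 to compound 2 cannot be read a step that the two limits leave unreadable from compound 1 to compound 2. For the measured compounds named here, compound 3 is the one compound with a number, and both steps toward it are downward: an at least 2.3-fold lower number from compound 1 to compound 3 (0.37 log units; beyond the scatter) and an at least 2.3-fold lower number from compound 2 to compound 3 (0.37 log units; beyond the scatter).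

Compound 4 `O=C1O[C@@H](CNC(=O)C(F)(F)F)CN1c1ccc(-n2cc(-c3ccccn3)cn2)c(F)c1` differs from compound 1 in one place: ((trifluoromethyl)carbonyl)amino in place of 4-hydroxypiperidin-1-yl on a saturated chain carbon bound to a saturated ring carbon. Going by the values given here, the measured step closest to this change is the one from compound 1 to compound 3, where a ((difluoromethyl)carbonyl)amino group enters at the same place and the number falls an at least 2.3-fold lower number from compound 1 to compound 3 (0.37 log units; beyond the scatter). Since the entering ((trifluoromethyl)carbonyl)amino group resembles that one, compound 4 is expected to step down from compound 1 in a similar way, an at least 2.0-fold lower number from compound 1 to compound 4 (0.30 log units; that floor lies within the scatter), though the limit of compound 1 leaves the true size uncertain. The estimate for compound 4 in this assay is 200 ug/mL, with a likely range from 80 ug/mL to 400 ug/mL.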

Compound 4, half-maximal inhibitory concentration: > 400 ug/mL
Compound 4 gave a limit, no number (the forecaster's own chance of this, stated with the estimate: 40%); at least 2.0-fold (0.30 log units) between middle value and limit.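

For the compounds shown here, replacing one hydrogen of the difluoromethyl group with fluoro gives an at least 2.3-fold higher number from compound 3 to compound 4 (0.37 log units; beyond the scatter) in this assay and is the first readable step here that leads to a higher number. It shows that a fluorinated carbonylamino group at this place does not by itself bring the lower number, since compound 3 has a measured value while compound 4, which differs from it by that single atom, gives only a limit. Compound 3 therefore stands apart from the other three compounds, and this small change in the side chain is enough to separate it from compound 4, but the other two steps to compound 4 cannot be read, since compound 1, compound 2 and compound 4 all stand at the same limit: the limit of > 400 ug/mL in this assay, at which 3 of the 4 values shown sit.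

On these data alone, how far compound 4 lies past that limit stays unknown, so the size of the change from compound 3 could be much larger than the step shows. The compounds shown also leave open where an acetylamino group, with no fluorine on its methyl carbon, or a ((fluoromethyl)carbonyl)amino group would fall, and so whether the number follows the count of fluorine atoms at all.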